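From compound 3 to compound 4: a side chain removed

The source may report more compounds than this note shows. Statements on the series, on what has been measured and on what is new or still open speak of the compounds shown alone.

Compound 3 `CNC(=O)c1cc(C(=O)NCCC[C@H]2OC[C@H](N)CO2)cc2c1OC[C@H]2c1ccccc1` reads >= 153 ug/mL in a physicochemical assay for solubility (a higher number here means a more soluble compound, a lower number a less soluble compound), and this value is a limit, not a number. Compound 1 `CNC(=O)c1cc(C(=O)N[C@H]2[C@@H]3COC[C@@H]32)cc2c1OC[C@H]2c1ccccc1` reads >= 165 ug/mL in this assay and this value is also a limit. Compound 2 `CNC(=O)c1cc(C(=O)NC2CC2)cc2c1OC[C@H]2c1ccccc1` reads >= 190 ug/mL in this assay and this value is a limit as well. Compound 3 therefore cannot be ranked against the other two.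

The change to compound 4 `CNC(=O)c1cc(C(=O)NC)c2c(c1)[C@H](c1ccccc1)CO2` is a hydrogen atom in place of a group of 9 heavy atoms (6 carbon, 1 nitrogen, 2 oxygen; one six-membered non-aromatic ring with 2 hetero atoms), on a saturated chain carbon bound to an amide-type nitrogen and it sits on a saturated chain carbon bound to an amide-type nitrogen. Three measured steps also exchange a group on an amide-type nitrogen: a step that the two limits leave unreadable from compound 1 to compound 2 and a step that the two limits leave unreadable from compound 1 to compound 3 and a step that the two limits leave unreadable from compound 2 to compound 3 and none of them gives a size or a direction to carry over. No step beyond the scatter is therefore expected in this assay and the estimated change is a step that the limit leaves unreadable from compound 3 to compound 4 without a firm direction. For compound 4 the expected value is 170 ug/mL with an estimated range from 110 ug/mL to 260 ug/mL and a report of only a limit is likely.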

Compound 4, solubility: >= 130 ug/mL
Compound 4: a limit, no number; the forecaster's own chance of this, stated with the estimate: 70%; the middle value is on the limit's open side.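

In this assay compound 4 gives >= 130 ug/mL, a limit and not a number, so its steps from compound 1, compound 2 and compound 3, all likewise limits, cannot be read. The compounds shown leave open whether exchanging the group on the amide-type nitrogen moves the read-out in this assay at all.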